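Working notes: methoxy removal on the cinnamoyl aryl ring

This account rests on a few compounds, and the source may have more. Where it says the series, first, only, none or still open, it means among the compounds named here.

Measured so far:
- compound 1 `COc1ccc(C(=O)c2cc(OC)c(OC)c(OC)c2)cc1NC(=O)/C=C/c1ccc(F)cc1` gives 3400 nM in a functional assay on COLO 205 cells (Homo sapiens) for cytotoxicity, read by MTT assay, with a stated time of 72 h; a lower number here means a stronger inhibitor, a higher number a weaker inhibitor
- compound 2 `COc1cc(/C=C/C(=O)Nc2cc(C(=O)c3cc(OC)c(OC)c(OC)c3)ccc2OC)ccc1F` gives 11800 nM in this assay
- compound 3 `COc1ccc(/C=C/C(=O)Nc2cc(C(=O)c3cc(OC)c(OC)c(OC)c3)cc(OC)c2OC)cc1OC` gives 5700 nM in this assay

Compound 1 and compound 3 sit within the scatter of each other, so no order between them is claimed. Compound 3 shows a lower number than compound 2, beyond the scatter; the difference between the cores of compound 2 and compound 3 is not broken down here.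

One change is measured: from compound 2 to compound 1, (hydrogen in place of methoxy on an aromatic carbon), giving a 3.5-fold lower number from compound 2 to compound 1 (0.54 log units; beyond the scatter).

Compound 4 `COc1ccc(/C=C/C(=O)Nc2cc(C(=O)c3cc(OC)c(OC)c(OC)c3)cc(OC)c2OC)cc1` has not been measured. It arises from compound 3 by hydrogen in place of methoxy on an aromatic carbon. Around the place the two cases differ: in compound 2 the leaving methoxy is ortho to a fluoro group, in compound 3 it is ortho to a methoxy group. The change is therefore the same kind of change, not the same.

For compound 4 a step of a 2.3-fold lower number from compound 3 to compound 4 (0.36 log units; beyond the scatter) in this assay is expected, resting on the single measured case, the step from compound 2 to compound 1 of a 3.5-fold lower number from compound 2 to compound 1 (0.54 log units; beyond the scatter). Among the measured compounds shown here, only one such example exists and its surroundings differ, so the expectation is tempered. Compound 4 is estimated at 2500 nM, with a likely range from 900 nM to 7000 nM.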

Compound 4, half-maximal inhibitory concentration: 4800 nM
Estimate against measurement, compound 4: 1.9-fold (0.28 log units) below; the range from low to high includes it.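

In this assay, replacing one methoxy by hydrogen, which turns 3,4-dimethoxyphenyl into 4-methoxyphenyl, gives a 1.2-fold lower number from compound 3 to compound 4 (0.07 log units; within the scatter), so on this core the change has no readable effect. The change therefore does not carry over at a constant size between the two cores: the same change on two cores in this assay, a 3.5-fold lower number (0.54 log units; beyond the scatter) from compound 2 to compound 1 and a 1.2-fold lower number (0.07 log units; within the scatter) from compound 3 to compound 4, 2.9-fold (0.47 log units) apart, beyond the scatter of two such steps

What the two pairs do not show is the source of that gap: it may follow the group ortho to the leaving methoxy, a fluoro group in compound 2 and a methoxy group in compound 3, or it may follow the rest of the core, and the two cannot be separated here.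

The compounds shown carry only methoxy, fluoro and hydrogen on this ring, so a hydroxyl group, an amine or a longer alkoxy chain such as ethoxy at this place remains open. Also open, on these data alone, is which of the two step sizes would be the more usual on a further core.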